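Swapping the aryl group on the sulfonyl of compound 1

This account rests on a few compounds, and the source may have more. Where it says the series, first, only, none or still open, it means among the compounds named here.

The compounds measured so far, in an assay on isolated protein for displacement of a labelled ligand from prostaglandin D2 receptor 2 (Homo sapiens); a higher number here means a weaker inhibitor, a lower number a stronger inhibitor:
compound 1 `COc1cccc(S(=O)(=O)c2c(C)n(CC(=O)O)c3ccc(C)cc23)c1` gives 71 nM;
compound 2 `Cc1ccc2c(c1)c(Sc1ccc(Cl)cc1)c(C)n2CC(=O)O` gives 15 nM;
compound 3 `Cc1c(Sc2ccc(Cl)cc2)c2cc(F)ccc2n1CC(=O)O` gives 1.6 nM.

Compound 1 has the highest number of the three. For the measured compounds named here, compound 2 is its nearest neighbour, and compound 3 its furthest, though compound 1 and compound 2 differ in more than one place, so no single-change step connects them. Going by the values given here, the only single-change step known is a 9.4-fold lower number from compound 2 to compound 3 (0.97 log units; beyond the scatter), which concerns the shared core, not the group on the sulfonyl sulfur.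

Compound 4 `Cc1ccc2c(c1)c(S(=O)(=O)c1ccccc1Cl)c(C)n2CC(=O)O` differs from compound 1 by 2-chlorophenyl in place of 3-methoxyphenyl on a sulfonyl sulfur. Among the compounds with values here, no measured step bears directly on this change. The expectation is therefore a step of a 1.2-fold lower number from compound 1 to compound 4 (0.07 log units; within the scatter), not clearly beyond the scatter. Compound 4 is estimated at 60 nM, with a range from 20 nM to 200 nM.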

Compound 4, half-maximal inhibitory concentration: 178 nM
Compound 4: middle estimate off by 3.0-fold (0.47 log units), on the low side, and the stated range covers the measured number.
By their numbers in this assay, from the lowest: compound 3; then compound 2; then compound 1; then compound 4.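

In this assay, the group on the sulfonyl sulfur clearly matters: 2-chlorophenyl in place of 3-methoxyphenyl gives a 2.5-fold higher number from compound 1 to compound 4 (0.40 log units; beyond the scatter), a modest step but beyond the scatter. For the compounds shown here, this is the first single-change step at this position, since the earlier step concerned the shared core. No available evidence explains this step. Because the methoxy group leaves and a chlorine enters, the data cannot separate the effects of the two. A plain phenyl on the sulfonyl sulfur would show how either group compares with no substituent at all.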